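Lengthening the dialkylamino chain on the sulfonyl sulfur

This account rests on a few compounds, and the source may have more. Where it says the series, first, only, none or still open, it means among the compounds named here.

Compounds measured so far:
compound 1, `CC(C)c1cccc(C(C)C)c1NC(=O)NS(=O)(=O)N(CC1CCCO1)CC1CCCO1`: 1700 nM
compound 2, `Cc1cc(C(C)(C)C)c(OC(=O)NS(=O)(=O)N(C(C)C)C(C)C)c(C(C)(C)C)c1`: 3200 nM
compound 3, `CCCCN(CCCC)S(=O)(=O)NC(=O)Oc1c(C(C)(C)C)cc(C)cc1C(C)(C)C`: 3200 nM

In an assay on liver for inhibition of sterol O-acyltransferase 1 (Rattus norvegicus), using microsomes (on this read-out lower numbers stand for stronger inhibition and higher numbers for weaker inhibition), compound 3 gives 3200 nM. Compound 2, which shares the carbamate core with it, gives 3200 nM in this assay, so the two stand level at the digits shown and together form the upper end of the three numbers. Compound 1, built on a urea rather than a carbamate, gives 1700 nM, and the gap to compound 3 is within the usual scatter, so no order among the three can be claimed.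

Compound 4, `CCCCCN(CCCCC)S(=O)(=O)NC(=O)Oc1c(C(C)(C)C)cc(C)cc1C(C)(C)C`, is the next member of the carbamate series. The change from compound 3 is dipentylamino in place of dibutylamino on a sulfonyl sulfur. Among the measured compounds shown here, only one measured step bears on it: no change at the digits printed from compound 2 to compound 3 (within the scatter), where exchanging one dialkylamino group for another on the same sulfonyl sulfur left the number unchanged. A further lengthening of both chains by one carbon each is a smaller alteration than that exchange, so no step beyond the scatter is expected in this assay. For compound 4 the expected step is a 1.1-fold lower number from compound 3 to compound 4 (0.03 log units; within the scatter). Compound 4 is therefore estimated at 3000 nM, with a range from 1200 nM to 8000 nM.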

Compound 4, half-maximal inhibitory concentration: 2200 nM
Compound 4: the middle estimate sits 1.4-fold (0.13 log units) above what was measured; low and high end bracket the measured number.
By their numbers in this assay, from the lowest: compounds 1, 4, 2 and 3 (each within the scatter of the next).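

In this assay, dipentylamino in place of dibutylamino on a sulfonyl sulfur gives a 1.5-fold lower number from compound 3 to compound 4 (0.16 log units; within the scatter) and dipentylamino in place of diisopropylamino gives a 1.5-fold lower number from compound 2 to compound 4 (0.16 log units; within the scatter) on the same carbamate core. The earlier compounds shown here offered a single exchange at this position, whereas compound 2, compound 3 and compound 4 now give three pairings of diisopropylamino, dibutylamino and dipentylamino, and none of them leaves the scatter, even with the 11 heavy atoms of dipentylamino against the 9 of dibutylamino. No measurement is at hand that would explain this result or say what this position contributes to the read-out.

On these data alone, the three dialkylamino groups therefore set no order among themselves, and it remains open whether a longer chain such as dioctylamino, or a ring such as piperidine or morpholine on the sulfonyl sulfur, would produce a step beyond the scatter. Also open, as far as these compounds go, is whether dipentylamino would behave the same way on the urea core of compound 1, which differs from these carbamates in more than one place and so allows no direct comparison.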